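A few compounds are considered here, and "the series" means these few. Any claim that something is new, unique, unknown or untested is made for them only; others in the source may bear on it.

Measured in an assay on HEK293 cells for binding affinity to corticotropin-releasing factor receptor 1 (Homo sapiens), read by radioligand binding; on this read-out lower numbers stand for stronger inhibition and higher numbers for weaker inhibition:
compound 1 `CCCN(CCC)c1nc(C)nc2c1n(C)c(=O)n2-c1ccc(C(C)C)cc1Br` gives 7.6 nM
compound 2 `CCCN(CC1CC1)c1nc(C)nc2c1n(C)c(=O)n2-c1ccc(C(C)C)cc1Br` gives 5.7 nM
compound 3 `CCCN(CC1CC1)c1nc(C)nc2c1n(C)c(=O)n2-c1c(C)cc(C)nc1C` gives 113 nM

Compound 4 `CCCN(CCC)c1nc(C)nc2c1n(C)c(=O)n2-c1c(C)cc(C)nc1C` has not yet been measured in this assay.

The change from compound 2 to compound 1 is ethyl in place of cyclopropyl on a saturated chain carbon bound to a nitrogen on an aromatic ring; it made a step of a 1.3-fold higher number from compound 2 to compound 1 (0.12 log units; within the scatter). Compound 3 carries the second core: against compound 2 the difference is 2,4,6-trimethylpyridin-3-yl in place of 2-bromo-4-isopropylphenyl on an aromatic nitrogen, and this step was a 20-fold higher number from compound 2 to compound 3 (1.30 log units; beyond the scatter), so compound 3 has the highest number of the three measured.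

Compound 4 is reached from compound 3 by ethyl in place of cyclopropyl on a saturated chain carbon bound to a nitrogen on an aromatic ring. The place is the same word for word as for the change from compound 2 to compound 1, so this is the same change, now made on the core of compound 3. Among the compounds with values here, the only measured instance of it is within the scatter, and nothing here shows that the two cores respond differently to it, although only one instance is available.

From compound 3 to compound 4 the expected step in this assay is a 1.3-fold higher number from compound 3 to compound 4 (0.12 log units; within the scatter), resting on a 1.3-fold higher number from compound 2 to compound 1 (0.12 log units; within the scatter) and on the value of compound 3 of 113 nM. Compound 4 is therefore estimated at 150 nM, with a likely range of 60 nM to 380 nM.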

Compound 4, inhibition constant: 259 nM
For compound 4 the middle estimate is 1.7-fold (0.24 log units) below the measured one; measured number inside the range.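

In this assay the second instance of ethyl in place of cyclopropyl makes a 2.3-fold higher number from compound 3 to compound 4 (0.36 log units; beyond the scatter), a modest step on this core. Set beside the first instance, the two steps cannot be told apart: the same change on two cores in this assay, a 1.3-fold higher number (0.12 log units; within the scatter) from compound 2 to compound 1 and a 2.3-fold higher number (0.36 log units; beyond the scatter) from compound 3 to compound 4, 1.7-fold (0.24 log units) apart, within the scatter of two such steps. The change therefore carries from one core to the other with no detectable difference in size, although one step lies within the scatter and the other beyond it; two instances on two cores do not establish a constant step across the series, nor do they exclude a small dependence on the core.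

The compounds shown leave open how the same amine position responds to other groups, such as a longer chain like butyl or a larger ring like cyclobutyl, on either core. Also open, going by these compounds, is whether the change behaves the same way with a third aromatic group on the aromatic nitrogen, such as a methoxyphenyl.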